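Swapping Cyclohexyl for Thiophen-3-yl on a Shared Core

The source may report more compounds than this note shows. Statements on the series, on what has been measured and on what is new or still open speak of the compounds shown alone.

Compound 2 `COC(=O)c1nc(C2CCCCC2)n(-c2ccc(F)cc2)n1` was tested in a functional assay on NPC-TW01 cells (Homo sapiens) for inhibition, read by MTT assay, with a stated time of 72 h (a higher number here means a weaker inhibitor of growth, a lower number a stronger inhibitor of growth), and gave 30500 nM. Among the two compounds measured so far, compound 2 has the highest number. For the measured compounds named here, its only neighbour, compound 1 `COC(=O)c1nc(C)n(-c2ccc(F)cc2)n1`, gave 15200 nM in this assay, and the step of a 2.0-fold higher number from compound 1 to compound 2 (0.30 log units; within the scatter) lies within the scatter, so the two compounds cannot be told apart on these numbers.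

Compound 3 `COC(=O)c1nc(-c2ccsc2)n(-c2ccc(F)cc2)n1` has not yet been measured. It differs from compound 2 in one place: thiophen-3-yl in place of cyclohexyl on an aromatic carbon. Going by the values given here, no measured step covers this exact exchange. Among the compounds with values here, the only measured step that touches the same position, a 2.0-fold higher number from compound 1 to compound 2 (0.30 log units; within the scatter), shows that exchanging the group on that aromatic carbon produced no difference beyond the scatter. Within the data shown here, since that is the only guidance available, the expected step is a 1.5-fold lower number from compound 2 to compound 3 (0.18 log units; within the scatter), which amounts to no change beyond the scatter. Compound 3 is therefore expected to give about 20000 nM in this assay, with a range from 7000 nM to 60000 nM.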

Compound 3, concentration for 50% growth inhibition: 10700 nM
For compound 3 the middle estimate is 1.9-fold (0.27 log units) above the measured one, and the stated range covers the measured number.
By their numbers in this assay, from the lowest: compounds 3, 1 and 2 (each within the scatter of the next, the first and the last beyond it).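

In this assay, for the compounds shown here, putting thiophen-3-yl where cyclohexyl stood gives a 2.9-fold lower number from compound 2 to compound 3 (0.45 log units; beyond the scatter), the first step at this position that lies beyond the scatter, though only a modest one. Thiophen-3-yl and methyl cannot be told apart, with a 1.4-fold lower number from compound 1 to compound 3 (0.15 log units; within the scatter), so the position responds to the group it carries only in the comparison between the five-membered aromatic ring and the six-membered non-aromatic ring of carbon only. Nothing available here explains why this exchange shifts the number.

With a single aromatic ring at this position, the compounds shown leave open whether the effect belongs to thiophen-3-yl itself or whether another aromatic ring, such as phenyl or thiophen-2-yl, would read the same. They also do not show how an amine or a carboxylic acid on this aromatic carbon would read, or whether the step between cyclohexyl and thiophen-3-yl would hold if the methoxycarbonyl group or the 4-fluorophenyl group were replaced.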